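Hydroxy for fluoro on the aryl sulfone of compound 3

A few compounds are considered here, and "the series" means these few. Any claim that something is new, unique, unknown or untested is made for them only; others in the source may bear on it.

Compound 1 `CSc1nn2cccnc2c1S(=O)(=O)c1cccc(Cl)c1`: 15.1 nM
Compound 2 `CSc1nn2c(C)cc(C)nc2c1S(=O)(=O)c1ccc(Cl)cc1`: 3.16 nM
Compound 3 `CNc1nn2c(C)cc(C)nc2c1S(=O)(=O)c1ccc(F)cc1`: 0.398 nM

In a functional assay on HEK293 cells for antagonist activity at 5-hydroxytryptamine receptor 6 (Homo sapiens), read by cAMP accumulation, with a stated time of 2 h (on this read-out higher numbers stand for weaker inhibition and lower numbers for stronger inhibition), compound 3 gives the lowest number of the three, and its gaps to compound 2 and to compound 1 both lie beyond the scatter. Compound 4 `CNc1nn2c(C)cc(C)nc2c1S(=O)(=O)c1ccc(O)cc1` is not yet measured. It differs from compound 3 in one place: hydroxy in place of fluoro on an aromatic carbon, on the six-membered aromatic ring of carbon only that carries the sulfone. Within the data shown here, no measured pair in this set makes this change, so its effect here is unknown. A hydroxy in place of a fluoro is expected to give a modest step toward a higher number, of the order of a 3.8-fold higher number from compound 3 to compound 4 (0.58 log units; beyond the scatter), possibly just beyond the scatter. Compound 4 is therefore estimated at 1.5 nM, in a range from 0.3 nM to 8 nM.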

Compound 4, inhibition constant: 2 nM
Compound 4: middle estimate off by 1.3-fold (0.12 log units), on the low side; the range from low to high includes it.
By their numbers in this assay, from the lowest: compound 3; then compounds 4 and 2 (each within the scatter of the next); then compound 1.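

In this assay, among these compounds, placing hydroxy in place of fluoro on the sulfone's aromatic ring gives a 5.0-fold higher number from compound 3 to compound 4 (0.70 log units; beyond the scatter) as the first single-place step in this set. This position therefore responds to the change, though compound 4 at 2 nM remains a strong inhibitor. No available evidence explains the step.

On these data alone, whether a methoxy or an amine at this position would fall nearer to fluoro or to hydroxy remains open. So does whether the same change would give a similar step with a methylthio group in place of the methylamino group.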